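The source may hold more compounds than are shown below. What is called first, only, known or untested is meant among the compounds shown, and "the series" means these compounds.

The measured compounds:

compound 1, `COc1cc(-c2cc(/C=C/C(=O)c3ccc(N)cc3)[nH]n2)cc(OC)c1OC`: 4080 nM
compound 2, `COc1ccc(C(=O)/C=C/c2cc(-c3cc(OC)c(OC)c(OC)c3)n[nH]2)cc1OC`: 3340 nM
compound 3, `COc1ccc(-c2cc(/C=C/C(=O)c3ccc(N)cc3)[nH]n2)cc1OC`: 5660 nM

All three were tested in a functional assay on SK-MEL-28 cells (Homo sapiens) for inhibition, read by sulforhodamine B assay, with a stated time of 48 h; on this read-out lower numbers stand for stronger inhibition of growth and higher numbers for weaker inhibition of growth. In this assay compound 3 gives 5660 nM, compound 1 gives 4080 nM and compound 2 gives 3340 nM, and all three numbers lie within the usual scatter of one another.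

Compound 3 and compound 1 differ in one place only: methoxy in place of hydrogen on an aromatic carbon. The step that goes with this change is a 1.4-fold lower number from compound 3 to compound 1 (0.14 log units; within the scatter). Compound 1 and compound 2 also differ in one place, and that step is a 1.2-fold lower number from compound 1 to compound 2 (0.09 log units; within the scatter). Compound 2 and compound 3 differ in more than one place; the difference between the two cores is not broken down here, and their two values simply stand as given.

Compound 4, `COc1cc(C(=O)/C=C/c2cc(-c3cc(OC)c(OC)c(OC)c3)n[nH]2)cc(OC)c1OC`, has not yet been measured. It differs from compound 2 by methoxy in place of hydrogen on an aromatic carbon. For the measured compounds named here, this is the same change as the one from compound 3 to compound 1, and the surroundings of the place are described in the same words. Because the earlier step was a 1.4-fold lower number from compound 3 to compound 1 (0.14 log units; within the scatter), compound 4 is expected to come out close to compound 2, with an estimated step of a 1.2-fold lower number from compound 2 to compound 4 (0.08 log units; within the scatter). Compound 4 is therefore estimated at 2800 nM in this assay. For compound 4 the expected range runs from 1200 nM to 6500 nM, which rests on a single earlier example of this change and on the scatter of the measurement.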

Compound 4, concentration for total growth inhibition: 3330 nM
For compound 4 the middle estimate is 1.2-fold (0.08 log units) below the measured one; the range from low to high includes it.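

In this assay, methoxy in place of hydrogen on an aromatic carbon gives a 1.0-fold lower number from compound 2 to compound 4 (0.00 log units; within the scatter). Set beside the first example of this change, the new step agrees with it, and the two cores show no difference that can be told from ordinary measurement noise: the same change on two cores in this assay, a 1.4-fold lower number (0.14 log units; within the scatter) from compound 3 to compound 1 and a 1.0-fold lower number (0.00 log units; within the scatter) from compound 2 to compound 4, 1.4-fold (0.14 log units) apart, within the scatter of two such steps. So in these four compounds the change carries from one core to the other without any step beyond the scatter, but this does not show that the added methoxy has a real effect on growth inhibition, nor that the two steps are truly identical, since a small effect would be hidden in the scatter and two cores are a very small sample.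

The compounds shown leave open whether a different group at this place, such as an amine, a carboxylic acid, a chlorine atom or a longer chain like ethoxy, would give a step beyond the scatter. They also leave open whether the agreement between the two cores would hold on a third core, or for a change that moves the number by a larger amount.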